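Ester in place of the diethylaminoethyl amide

The compounds below may be only part of what the source reports. "The series", "measured", "known", "first", "only" and "open" are said of these compounds alone.

Compound 1 `CCN(CC)CCNC(=O)c1ccc(C(CC)(CC)c2ccc(OCC(O)C(C)(C)C)c(C)c2)n1CC` is the reference for this note. Within the data shown here, in a functional assay on MCF7 cells (Homo sapiens), read by MTT assay, with a stated time of 48 h (a higher number here means a weaker inhibitor, a lower number a stronger inhibitor), compound 1 gives 690 nM, the second highest of the three numbers so far. Compound 2 `CCn1c(C(=O)NCCN)ccc1C(CC)(CC)c1ccc(OCC(O)C(C)(C)C)c(C)c1` gives 5.9 nM in this assay, and compound 3 `CC[C@@H](C)[C@H](NC(=O)c1ccc(C(CC)(CC)c2ccc(OCC(O)C(C)(C)C)c(C)c2)n1CC)C(=O)O` gives 2000 nM. The known steps are a 120-fold lower number from compound 1 to compound 2 (2.07 log units; beyond the scatter) and a 2.9-fold higher number from compound 1 to compound 3 (0.46 log units; beyond the scatter); the step between the other two is a 340-fold higher number from compound 2 to compound 3 (2.53 log units; beyond the scatter).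

Compound 4 `CCn1c(C(=O)OCc2ccc(F)cc2)ccc1C(CC)(CC)c1ccc(OCC(O)C(C)(C)C)c(C)c1` is not yet measured. Relative to compound 1 the change is (4-fluorobenzyl)oxy in place of (2-(diethylamino)ethyl)amino on a carbonyl carbon. The steps measured to date all move the group on the amide-type nitrogen, and they show that this part of the molecule is sensitive: the small shift to the 2-aminoethyl chain in compound 2 brought a large gain, while the 1-carboxy-2-methylbutyl chain in compound 3 brought a modest loss. Compound 4 goes further than either, removing the chain nitrogen and the amide-type nitrogen together. No measured step covers an ester, so the direction is inferred, not shown. A step toward a higher number in this assay is expected for compound 4, of the order of a 3.6-fold higher number from compound 1 to compound 4 (0.56 log units; beyond the scatter). Compound 4 is therefore estimated at 2500 nM, with a range of 600 nM to 12000 nM.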

Compound 4, half-maximal inhibitory concentration: > 50000 nM
Compound 4: a limit, no number; the forecaster's own chance of this, stated with the estimate: 15%; middle value at least 20-fold (1.30 log units) away from the limit.
By their numbers in this assay, from the lowest: compound 2; then compound 1; then compound 3. At a limit, above all of these: compound 4.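

In this assay compound 4 stands at a limit of the assay and not at a number: the limit of > 50000 nM in this assay, at which 1 of the 4 values shown sits. The (4-fluorobenzyl)oxy group on the carbonyl carbon gives an at least 72-fold higher number from compound 1 to compound 4 (1.86 log units; beyond the scatter) and the comparison with the other two amides reads an at least 25-fold higher number from compound 3 to compound 4 (1.39 log units; beyond the scatter) and an at least 8400-fold higher number from compound 2 to compound 4 (3.92 log units; beyond the scatter) as the remaining steps of the series. The earlier compounds shown here showed only how far the result moves when the group on the amide-type nitrogen changes, and even compound 3, the highest number among them, still gives a numerical value, so the new result shows that replacing the whole amide-type nitrogen unit with this ester at the carbonyl carbon takes the series out of the measurable range.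

Compound 4 changes the atom on the carbonyl carbon and the chain together, so the compounds shown cannot separate the loss of the amide-type nitrogen from the loss of the chain amine or from the entry of the 4-fluorobenzyl group. As far as these compounds go, a 4-fluorobenzyl amide and a 2-aminoethyl ester would each change only one of these and remain open here.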